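The source may report more compounds than this note shows. Statements on the series, on what has been measured and on what is new or still open speak of the compounds shown alone.

Measured so far, in an assay on CV-1 cells with retinoic acid receptor gamma (Homo sapiens) as the target; a lower number here means that less compound is needed, a higher number that more compound is needed for the effect:

Compound 1 `CCCc1cc2c(cc1C(=O)c1ccc(C(=O)O)cc1)C(C)(C)CCC2(C)C` gives > 10000 nM; this is a limit of the assay, not a number.
Compound 2 `CC1(C)CCC(C)(C)c2cc(C(=O)c3ccc(C(=O)O)cc3)c(F)cc21` gives 1020 nM.
Compound 3 `C=C(c1ccc(C(=O)O)cc1)c1cc2c(cc1C(C)C)C(C)(C)CCC2(C)C` gives > 10000 nM; this too is a limit of the assay, not a number.

Compound 3 therefore stands only at a limit: of its own value nothing more is known than that it sits there, and it shares that position with one other compound, as noted in the limit of > 10000 nM in this assay, at which 2 of the 3 values shown sit. The step to compound 4 `C=C(c1ccc(C(=O)O)cc1)c1cc2c(cc1Br)C(C)(C)CCC2(C)C` consists of bromo in place of isopropyl on an aromatic carbon. Within the data shown here, one measured step bears on this: an at least 9.8-fold lower number from compound 1 to compound 2 (0.99 log units; beyond the scatter), where the number dropped from a limit into the measurable range. That step also exchanged an alkyl group on an aromatic carbon for a single halogen atom, so a move of comparable direction is expected here, though its size is uncertain because compound 3 is known only as > 10000 nM. Compound 4 is estimated at 2500 nM, within a range of 500 nM to 10000 nM. The expected step from compound 3 to compound 4 is thus an at least 4.0-fold lower number from compound 3 to compound 4 (0.60 log units; beyond the scatter), with a real chance that the assay again reports only a limit.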

Compound 4, half-maximal effective concentration: > 10000 nM
Compound 4 gave a limit, no number (the forecaster's own chance of this, stated with the estimate: 30%); middle value at least 4.0-fold (0.60 log units) from the limit.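

Compound 3 and compound 4 both sit at a limit of the assay rather than at a number, so no step between them can be read: the limit of > 10000 nM in this assay, at which 3 of the 4 values shown sit.

On these data alone, whether bromo in place of isopropyl on an aromatic carbon changes the number at all, and by how much, stays open.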